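Replacing the acetyl group of compound 3

The compounds below may be only part of what the source reports. "The series", "measured", "known", "first", "only" and "open" are said of these compounds alone.

Values in a physicochemical assay for solubility, read by chemiluminescence, measured as kinetic solubility; on this read-out higher numbers stand for higher solubility and lower numbers for lower solubility:
- Compound 1 `CC(=O)NCc1cccc(Cn2nc(NS(=O)(=O)c3ccc(Cl)s3)c3c(F)cccc32)c1`: >= 139 ug/mL, a limit
- Compound 2 `CC(=O)NCc1cccc(Cn2nc(NS(=O)(=O)c3ccc(Cl)s3)c3c(C#N)cccc32)c1`: >= 155 ug/mL, a limit
- Compound 3 `CC(=O)NCc1cccc(Cn2nc(NS(=O)(=O)c3ccc(Cl)s3)c3c(C(C)=O)cccc32)c1`: 57 ug/mL

Among the measured compounds shown here, compound 3 holds the only exact number here, and it is the lowest of the three. Compound 4 `CC(=O)NCc1cccc(Cn2nc(NS(=O)(=O)c3ccc(Cl)s3)c3c(C(C)(C)O)cccc32)c1` carries 1-hydroxy-1-methylethyl in place of acetyl on an aromatic carbon. Two measured steps change the group on that carbon: an at least 2.4-fold lower number from compound 1 to compound 3 (0.38 log units; beyond the scatter) and an at least 2.7-fold lower number from compound 2 to compound 3 (0.43 log units; beyond the scatter). Both start from a limit. For the measured compounds named here, no measured compound carries the new group, so no step beyond the scatter is expected in this assay from compound 3. Compound 3 stands at 57 ug/mL. The estimated step is a 1.4-fold higher number from compound 3 to compound 4 (0.15 log units; within the scatter). Compound 4 is expected at 80 ug/mL, with an estimated range of 35 ug/mL to 160 ug/mL.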

Compound 4, solubility: >= 159 ug/mL
Compound 4: no number, only a limit; the forecaster's own chance of this, stated with the estimate: 15%; middle value at least 1.9-fold (0.29 log units) away from the limit.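

In this assay, 1-hydroxy-1-methylethyl in place of acetyl gives an at least 2.7-fold higher number from compound 3 to compound 4 (0.44 log units; beyond the scatter). The earlier steps shown here at this aromatic carbon were only falls to compound 3, whereas this one is a rise from it, and the entering group carries a hydrogen-bond donor that acetyl lacks, though this single pair cannot tie the rise to that donor. The result for compound 4 is a limit, not a number: the limit of >= 159 ug/mL in this assay, at which 1 of the 4 values shown sits.

The steps from compound 1 and compound 2 to compound 4 cannot be read, since all three values are limits. On these data alone, how an amine or a carboxylic acid on this carbon would compare stays open.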